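Compound 4: carbamate-linked amine replaces the carboxamide

This account rests on a few compounds, and the source may have more. Where it says the series, first, only, none or still open, it means among the compounds named here.

Three compounds of the series carry numbers in an assay on CHO-K1 cells for displacement of a labelled ligand from prostaglandin E2 receptor EP1 subtype (Homo sapiens); on this read-out higher numbers stand for weaker inhibition and lower numbers for stronger inhibition. Compound 1 `Cc1cc(C(=O)NCc2cccnc2)nn1Cc1cc(Cl)ccc1OCc1ccccc1` gives 50.1 nM, the second highest of the three numbers. Compound 3 `Cc1cc(NC(=O)C2CCCC2)nn1Cc1cc(Cl)ccc1OCC(C)C` gives 25.1 nM, which lies within the scatter of compound 1. Compound 2 `Cc1cc(C(N)=O)nn1Cc1cc(Cl)ccc1OCC(C)C` gives 126 nM, beyond the scatter from compound 1. Among the measured compounds shown here, the single measured step is a 5.0-fold lower number from compound 2 to compound 3 (0.70 log units; beyond the scatter), with (cyclopentylcarbonyl)amino in place of carbamoyl on an aromatic carbon.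

Compound 4 `Cc1cc(NC(=O)OCc2ccccn2)nn1Cc1cc(Cl)ccc1OCc1ccccc1` is the next compound for this assay. Relative to compound 1 the change is (((pyridin-2-yl)methoxy)carbonyl)amino in place of ((pyridin-3-yl)methyl)carbamoyl on an aromatic carbon. The step from compound 2 to compound 3 bears on this: there too a carbamoyl group on the same aromatic carbon gave way to a nitrogen-linked carbonyl group, and the number fell by a 5.0-fold lower number from compound 2 to compound 3 (0.70 log units; beyond the scatter). For the measured compounds named here, the pyridine ring in compound 4 moves from the carbamoyl side to the carbamate side, and the amide is extended by one oxygen, for which no measured pair exists. For compound 4 a modest drop in the number is expected, a 2.0-fold lower number from compound 1 to compound 4 (0.30 log units; within the scatter), smaller than the measured step between compound 2 and compound 3. For compound 4 the estimated value is 25 nM, with an expected range from 8 nM to 80 nM.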

Compound 4, half-maximal inhibitory concentration: 79.4 nM
Estimate against measurement, compound 4: 3.2-fold (0.50 log units) below; low and high end bracket the measured number.
By their numbers in this assay, from the lowest: compounds 3, 1, 4 and 2 (each within the scatter of the next, the first and the last beyond it).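

In this assay the exchange on this aromatic carbon gives a 1.6-fold higher number from compound 1 to compound 4 (0.20 log units; within the scatter), so ((pyridin-3-yl)methyl)carbamoyl and (((pyridin-2-yl)methoxy)carbonyl)amino are not told apart on this read-out. A nitrogen-linked carbonyl group in place of a carbamoyl group therefore does not go with a step beyond the scatter in every pair: the earlier exchange, with a 5.0-fold lower number from compound 2 to compound 3 (0.70 log units; beyond the scatter), lies beyond it, while the new one stays within it. No measurement on hand accounts for the difference between these two steps.

On these data alone, the new step changes the direction of the link, adds an oxygen and moves the attachment of the pyridine ring all at once, so the share of each change remains open, and a urea with an amine nitrogen in place of the carbamate oxygen or a (pyridin-3-yl)methyl carbamate would help to separate them. As far as these compounds go, it also remains open whether (cyclopentylcarbonyl)amino on the core of compound 1, or a simple benzyl carbamate without the pyridine nitrogen, would give a number beyond the scatter of compound 1.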